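Trimming the biaryl of compound 1 to a bromo group

The source may hold more compounds than are shown below. What is called first, only, known or untested is meant among the compounds shown, and "the series" means these compounds.

Measured compounds:
- compound 1 `COC(=O)/C=C/c1cccc(N(Cc2ccc(-c3cccc(Cl)c3)cc2)C(=O)C2CCCCC2)c1`: 94 nM
- compound 2 `COC(=O)/C=C/c1cccc(N(Cc2ccc(-c3cccc(Cl)c3)cc2)C(=O)C(C)C)c1`: 77 nM
- compound 3 `COC(=O)/C=C/c1cccc(N(Cc2ccc(/C=C/C(=O)OC(C)(C)C)cc2)C(=O)c2ccccc2)c1`: 236 nM

In an assay on isolated protein with Bile acid receptor (Homo sapiens) as the target (on this read-out higher numbers stand for an effect only at larger amounts of compound and lower numbers for an effect already at smaller amounts), compound 1 gives 94 nM, the second highest of the three numbers; compound 2 sits within the scatter of it, and compound 3 lies beyond the scatter with a higher number. Compound 4 `COC(=O)/C=C/c1cccc(N(Cc2ccc(Br)cc2)C(=O)C2CCCCC2)c1` has not been measured. It differs from compound 1 at the aromatic carbon para to a large group: bromo in place of 3-chlorophenyl on an aromatic carbon. Among the measured compounds shown here, the only measured step, a 1.2-fold lower number from compound 1 to compound 2 (0.09 log units; within the scatter), concerns the group on the carbonyl carbon and so does not bear on this change; no step at this position has been measured. Compound 4 is therefore expected to give a higher number, by about a 3.7-fold higher number from compound 1 to compound 4 (0.57 log units; beyond the scatter), with an estimate of 350 nM and a range from 100 nM to 1500 nM.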

Compound 4, half-maximal effective concentration: > 1000 nM
Compound 4: a limit, no number; the forecaster's own chance of this, stated with the estimate: 5%; middle value at least 2.8-fold (0.45 log units) from the limit.
By their numbers in this assay, from the lowest: compounds 2 and 1 (each within the scatter of the next); then compound 3. At a limit, above all of these: compound 4.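

In this assay compound 4 gives a limit and not a number: the limit of > 1000 nM in this assay, at which 1 of the 4 values shown sits. At this position, bromo in place of 3-chlorophenyl brings an at least 10-fold higher number from compound 1 to compound 4 (1.02 log units; beyond the scatter), the first step measured here and a large one. The aromatic carbon para to a large group therefore does not tolerate every substituent equally, whereas the change on the carbonyl carbon from compound 1 to compound 2 stayed within the scatter. The compounds shown leave open whether an unsubstituted phenyl, a 4-chlorophenyl or a pyridine ring would hold the value of compound 1. They also leave open whether an amine or a carboxylic acid on the outer ring would do so.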